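Trifluoromethyl in Place of Fluoro on the Sulfonyl Ring

The source may hold more compounds than are shown below. What is called first, only, known or untested is meant among the compounds shown, and "the series" means these compounds.

In a functional assay on HCT-116 cells (Homo sapiens) for inhibition, read by MTT assay, with a stated time of 72 h (a lower number here means a stronger inhibitor, a higher number a weaker inhibitor), compound 3 `Cc1c(C(=O)O)oc2ccc(N(Cc3ccccc3)S(=O)(=O)c3ccc(F)cc3)cc12` reaches only (the limit of > 40000 nM in this assay, at which 1 of the 3 values shown sits), so its value of > 40000 nM is a limit and not a number. Compound 2 `Cc1c(C(=O)O)oc2ccc(N(Cc3ccccc3)S(=O)(=O)c3ccc(Br)cc3)cc12`, which carries bromo in the same place, gives 20000 nM, and the step of an at least 2.0-fold higher number from compound 2 to compound 3 (0.30 log units; that floor lies within the scatter) reaches just the edge of the usual scatter. Compound 1 `CCOC(=O)c1oc2ccc(N(Cc3ccccc3)S(=O)(=O)c3ccc(C(F)(F)F)cc3)cc2c1C`, an ethyl ester already bearing trifluoromethyl, gives 12700 nM. Compound 4 `Cc1c(C(=O)O)oc2ccc(N(Cc3ccccc3)S(=O)(=O)c3ccc(C(F)(F)F)cc3)cc12` differs from compound 3 by trifluoromethyl in place of fluoro on an aromatic carbon. For the measured compounds named here, only the step from compound 2 to compound 3 bears on this change, and because that step an at least 2.0-fold higher number from compound 2 to compound 3 (0.30 log units; that floor lies within the scatter) ran toward weaker inhibition when fluoro replaced bromo, compound 4 is expected to move back, a step of an at least 2.0-fold lower number from compound 3 to compound 4 (0.30 log units; that floor lies within the scatter). Compound 4 is therefore estimated at 20000 nM, between 8000 nM and 50000 nM.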

Compound 4, half-maximal inhibitory concentration: 21100 nM
Compound 4: middle estimate off by 1.1-fold (0.02 log units), on the low side; measured number inside the range.
By their numbers in this assay, from the lowest: compounds 1, 2 and 4 (each within the scatter of the next). At a limit, above all of these: compound 3.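

In this assay, trifluoromethyl and bromo at this position read alike, with a 1.1-fold higher number from compound 2 to compound 4 (0.02 log units; within the scatter), and with trifluoromethyl in place, the ethyl ester and the free acid also read alike, with a 1.7-fold higher number from compound 1 to compound 4 (0.22 log units; within the scatter). Against fluoro, the comparison gives only a floor, with an at least 1.8-fold lower number from compound 3 to compound 4 (0.27 log units; that floor lies within the scatter). Compound 3 stands at a limit and not at a number: the limit of > 40000 nM in this assay, at which 1 of the 4 values shown sits.

From the compounds shown here alone, how far fluoro truly differs from bromo and trifluoromethyl stays open. So does what an amine or a methoxy group at this position would give.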